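Dropping the benzyl from a phenol ether: an expected cell result

The compounds below may be only part of what the source reports. "The series", "measured", "known", "first", "only" and "open" are said of these compounds alone.

Measured so far:
- compound 1 `CS(=O)(=O)N1CC(CCl)c2cc([N+](=O)[O-])c(O)cc21`: 8.85 ug/mL
- compound 2 `CS(=O)(=O)N1CC(CCl)c2cc(C=O)c(OCc3ccccc3)cc21`: 3.24 ug/mL

In a functional assay on KB cells (Homo sapiens), read by crystal violet staining (on this read-out higher numbers stand for weaker inhibition and lower numbers for stronger inhibition), compound 2 stands with the lowest of the two numbers, and compound 1 gives a higher number, a difference beyond the usual scatter of this read-out. Compound 3 `CS(=O)(=O)N1CC(CCl)c2cc(C=O)c(O)cc21` has not been measured yet. It differs from compound 2 in one place: hydrogen in place of benzyl on an oxygen on an aromatic ring. Among the measured compounds shown here, no pair of measured compounds differs by exactly this change, so the size of its effect is not known from these data. For the measured compounds named here, compound 1, the only measured compound carrying a free hydroxy group, gives 8.85 ug/mL, but it also carries a different second group, so it cannot settle the question. On balance a moderate rise in the number is expected, that is somewhat weaker inhibition, with wide uncertainty. For compound 3 the estimate is 6.5 ug/mL, within a range of 2 ug/mL to 20 ug/mL, which would mean an expected step of a 2.0-fold higher number from compound 2 to compound 3 (0.30 log units; within the scatter).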

Compound 3, half-maximal inhibitory concentration: 4.83 ug/mL
The estimate for compound 3 lay 1.3-fold (0.13 log units) above the measured number; the range from low to high includes it.
By their numbers in this assay, from the lowest: compounds 2, 3 and 1 (each within the scatter of the next, the first and the last beyond it).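

In this assay, taking the benzyl off the oxygen gives a 1.5-fold higher number from compound 2 to compound 3 (0.17 log units; within the scatter), so on this read-out benzyloxy and hydroxy cannot be told apart at this position, and the one-place change leaves inhibition within the range of repeat measurements. With the hydroxy kept, formyl in place of nitro on the aromatic carbon gives a 1.8-fold lower number from compound 1 to compound 3 (0.26 log units; within the scatter), so this single change cannot be told apart from the scatter either. Nothing available offers an explanation for either result.

The compounds shown leave open how other groups on this oxygen would behave, such as a methyl or an acetyl, and whether an amine in place of the hydroxy would keep the number in this range. They also leave open whether a carboxylic acid in place of the formyl would shift the number beyond the scatter.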